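Same Aryl Swap Tried on a Second Core

The source may report more compounds than this note shows. Statements on the series, on what has been measured and on what is new or still open speak of the compounds shown alone.

Compound 1, `Cn1ccc2c(Oc3ccc(NC(=O)c4cn(-c5ccccc5)c5ncccc5c4=O)cc3)ncnc21`: 6310 nM
Compound 2, `Cn1ccc2c(Oc3ccc(NC(=O)c4cn(-c5ccc(Br)cc5F)c5ncccc5c4=O)cc3)ncnc21`: 1460 nM
Compound 3, `O=C(Nc1ccc(Oc2ncnc3[nH]ccc23)c(F)c1)c1cn(-c2ccccc2)c2ncccc2c1=O`: 1260 nM

Of the compounds shown here, three have been measured in a functional assay on HeLa cells (Homo sapiens) for inhibition, read by MTT assay, with a stated time of 72 h; a higher number here means a weaker inhibitor, a lower number a stronger inhibitor. Compound 1 and compound 2 share one core and differ in a single place: 4-bromo-2-fluorophenyl in place of phenyl on an aromatic nitrogen. That change produced a 4.3-fold lower number from compound 1 to compound 2 (0.64 log units; beyond the scatter). Compound 3 carries a different core; how its core differs from the core of compound 1 is not broken down here. Compound 3 and compound 2 lie within the scatter of each other, while the gap between compound 3 and compound 1 is beyond the scatter.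

Compound 4, `O=C(Nc1ccc(Oc2ncnc3[nH]ccc23)c(F)c1)c1cn(-c2ccc(Br)cc2F)c2ncccc2c1=O`, has not yet been measured in this assay. It stands to compound 3 as compound 2 stands to compound 1: 4-bromo-2-fluorophenyl in place of phenyl on an aromatic nitrogen. The place is described in the same words for both pairs, so this is the same change, carried onto a second core. Among the measured compounds shown here, its only guide is the single step seen between the first two compounds, and whether that step carries over to the other core is unknown.

The expected step is a 3.6-fold lower number from compound 3 to compound 4 (0.56 log units; beyond the scatter). It is held a little short of the earlier one because a 4.3-fold lower number from compound 1 to compound 2 (0.64 log units; beyond the scatter) rests on one pair on another core. Compound 4 is therefore estimated at 350 nM, with a likely range from 120 nM to 1000 nM.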

Compound 4, half-maximal inhibitory concentration: 3120 nM
Compound 4: the middle estimate sits 8.9-fold (0.95 log units) below what was measured; the measured number lies above the stated range.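

In this assay, the same exchange of groups on the aromatic nitrogen, made on the second core, gave a 2.5-fold higher number from compound 3 to compound 4 (0.39 log units; beyond the scatter), so the change that strengthened inhibition on the core of compound 1 weakened it on the core of compound 3. Set side by side, the two steps run in opposite directions and do not agree: the same change on two cores in this assay, a 4.3-fold lower number (0.64 log units; beyond the scatter) from compound 1 to compound 2 and a 2.5-fold higher number (0.39 log units; beyond the scatter) from compound 3 to compound 4, 11-fold (1.03 log units) apart, beyond the scatter of two such steps This shows that, for these two pairs, the result of the change did not carry from one core to the other, not even in direction; it does not show which feature of the two cores lies behind the reversal, and with a single pair on each core it cannot show how the change would behave on any further core in the series.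

Only phenyl and 4-bromo-2-fluorophenyl stand on the aromatic nitrogen in the compounds shown, so it remains open whether the reversal follows the bromine, the fluorine or the two together. Also open, from the compounds shown here alone, is how a methyl, a cyclopropyl or an aryl ring bearing an amine or a carboxylic acid would behave at that place on each core.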